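Piperidine-capped aminoindanone analogues: pyrimidine to oxadiazole swap

The compounds below may be only part of what the source reports. "The series", "measured", "known", "first", "only" and "open" are said of these compounds alone.

Three compounds carry the same propyl-linked piperidine amine motif. Among the measured compounds shown here, compound 1 `CC(C)(C)OC(=O)N1CCC(CCCNc2ccc3c(c2)NNS3(=O)=O)CC1` gives 268 nM in a functional assay on CHO-K1 cells for agonist activity at Glucose-dependent insulinotropic receptor (Homo sapiens), read by HTRF and cAMP accumulation, with a stated time of 30 min (on this read-out higher numbers stand for an effect only at larger amounts of compound and lower numbers for an effect already at smaller amounts), compound 2 `CC(C)(C)OC(=O)N1CCC(CCCNc2ccc3c(c2)CNC3=O)CC1` gives 550 nM in this assay, and compound 3 `CCc1cnc(N2CCC(CCCNc3ccc4c(c3)OCC4=O)CC2)nc1` gives 117 nM, the lowest number of the three and beyond the scatter from both others, so compound 3 stands as the most potent compound measured so far. Compound 4 `CC(C)c1noc(N2CCC(CCCNc3ccc4c(c3)OCC4=O)CC2)n1` differs from compound 3 by 3-isopropyl-1,2,4-oxadiazol-5-yl in place of 5-ethylpyrimidin-2-yl on an amine nitrogen in a ring. For the measured compounds named here, no measured pair isolates this kind of change, so the direction of the step is not predictable from the data; the expectation is a step no larger than the scatter, a 1.3-fold higher number from compound 3 to compound 4 (0.11 log units; within the scatter). Compound 4 is therefore estimated at 150 nM in this assay, with a range from 50 nM to 450 nM.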

Compound 4, half-maximal effective concentration: 73 nM
For compound 4 the middle estimate is 2.1-fold (0.31 log units) above the measured one; the measured number falls inside the stated range.
By their numbers in this assay, from the lowest: compounds 4 and 3 (each within the scatter of the next); then compound 1; then compound 2.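

Among the compounds shown here, this is the first matched pair at the amine nitrogen in the six-membered non-aromatic ring. In this assay the step with 3-isopropyl-1,2,4-oxadiazol-5-yl in place of 5-ethylpyrimidin-2-yl (a 1.6-fold lower number from compound 3 to compound 4 (0.20 log units; within the scatter)) shows that a five-membered aromatic ring can replace the six-membered one here without a separation beyond the scatter. No measured data bear on what lies behind this step.

Still open, on these data alone, is whether a carboxylic acid or a primary amine on this nitrogen would stay in the same range. As far as these compounds go, the cores of compound 1 and compound 2 also remain untested with either aromatic ring on this nitrogen.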